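The compounds below may be only part of what the source reports. "The series", "measured", "known", "first", "only" and "open" are said of these compounds alone.

The measured compounds:
Compound 1, `Cc1cc(CCC#N)cc(C)c1Oc1cc(Nc2ccc(C#N)cc2)c(N)cc1CO`, gives 3.68 in a physicochemical assay for lipophilicity, at pH 7.4; a higher number here means a more lipophilic compound, a lower number a more polar compound.
Compound 2, `Cc1cc(CCC#N)cc(C)c1Oc1cc(Nc2ccc(C#N)cc2)c(N)cc1C(F)(F)F`, reaches only a limit of this assay, namely > 5.
Compound 3, `Cc1cc(/C=C/C#N)cc(C)c1Oc1cc(Nc2ccc(C#N)cc2)c(N)cc1C(F)(F)F`, likewise reaches only a limit, > 5.

Compound 2 and compound 3 share everything except one change in the core: 2-cyanoethenyl in place of 2-cyanoethyl on an aromatic carbon. The step between them in this assay is a step that the two limits leave unreadable from compound 2 to compound 3, since both values sit at the limit of > 5 in this assay, at which 2 of the 3 values shown sit. From compound 2 to compound 1 the change is hydroxymethyl in place of trifluoromethyl on an aromatic carbon, and it produces a number at least 1.32 log units lower from compound 2 to compound 1 (beyond the scatter).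

Compound 4, `Cc1cc(/C=C/C#N)cc(C)c1Oc1cc(Nc2ccc(C#N)cc2)c(N)cc1CO`, has not yet been measured. It differs from compound 3 by hydroxymethyl in place of trifluoromethyl on an aromatic carbon, the same change that was made from compound 2 to compound 1, set on the core of compound 3. The step in this assay is expected to be a number at least 1.40 log units lower from compound 3 to compound 4 (beyond the scatter), resting on a number at least 1.32 log units lower from compound 2 to compound 1 (beyond the scatter) and on the near identity of the two cores. Compound 4 is therefore estimated at 3.6, with a range from 3.1 to 4.2.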

Compound 4, partition coefficient: 4.14
For compound 4 the middle estimate is 0.54 log units below the measured one, within the range that was stated.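

In this assay, hydroxymethyl in place of trifluoromethyl lowers the number on both cores, with a number at least 0.86 log units lower from compound 3 to compound 4 (beyond the scatter) and, on the other core, a number at least 1.32 log units lower from compound 2 to compound 1 (beyond the scatter), so the direction of the change carries over between these two pairs. The true size of neither step can be read, and the two cannot be compared, because compound 2 and compound 3 both start from a limit rather than a number: the limit of > 5 in this assay, at which 2 of the 4 values shown sit. The same limit leaves the step between those two compounds unreadable, so 2-cyanoethenyl in place of 2-cyanoethyl can be read only on the hydroxymethyl pair, as a number 0.46 log units higher from compound 1 to compound 4 (beyond the scatter), and whether it does the same beside trifluoromethyl is not shown.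

The compounds shown leave open whether an amine, a carboxylic acid or a longer chain in that place would follow the same direction. Among the compounds shown here, they also cover only two closely related cores, so they do not show whether the change would carry over to any other core.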